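The source may hold more compounds than are shown below. What is called first, only, known or untested is meant among the compounds shown, and "the series" means these compounds.

Three compounds have been measured in an assay (Cricetulus griseus) for inhibition of aldehyde dehydrogenase, mitochondrial (Homo sapiens); a higher number here means a weaker inhibitor, a lower number a stronger inhibitor:

compound 1 `O=c1c(-c2ccc(O)cc2)coc2cc(OCCCCCCCCCCCCO)ccc12`: 1700 nM
compound 2 `O=C(O)CCCCCOc1ccc2c(=O)cc(-c3ccc(O)cc3)oc2c1`: 3500 nM
compound 3 `CCCCCCC(Oc1ccc2c(=O)c(-c3ccc(O)cc3)coc2c1)C(=O)O`: 2000 nM

Compound 1 has the lowest of these three numbers. Compound 3 comes nearest, and its gap to compound 1 lies within the usual scatter; compound 2 stands furthest, its gap to compound 1 just beyond the scatter. Compound 4 `O=C(O)CCCCCCCOc1ccc2c(=O)c(-c3ccc(O)cc3)coc2c1` has not yet been measured in this assay. Against compound 1 it shows (carboxy in place of 5-hydroxypentyl on a saturated chain carbon, seven bonds along the chain from an oxygen on an aromatic ring). Among the compounds with values here, no step between measured compounds is available for this change, so the expectation rests on compound 2 and compound 3, the two measured compounds that also carry a carboxy and give numbers no lower than compound 1. The step from compound 1 to compound 4 is therefore expected to be a small rise, a 1.5-fold higher number from compound 1 to compound 4 (0.17 log units; within the scatter), of about the size of the scatter. Compound 4 is estimated at 2500 nM, in a range from 1200 nM to 5200 nM.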

Compound 4, half-maximal inhibitory concentration: 40 nM
Beside the measured number, compound 4's estimate is 63-fold (1.80 log units) above it; the whole stated range lies above it.
By their numbers in this assay, from the lowest: compound 4; then compounds 1, 3 and 2 (each within the scatter of the next, the first and the last beyond it).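

In this assay, carboxy in place of 5-hydroxypentyl on a saturated chain carbon, seven bonds along the chain from an oxygen on an aromatic ring, gives a large step (a 43-fold lower number from compound 1 to compound 4 (1.63 log units; beyond the scatter)). Within the data shown here, the number at this position therefore responds strongly to what ends the chain, a dependence that the earlier compounds could not show. No measurement at hand bears on the cause of this step.
Going by these compounds, the change alters the chain end and its length together, so their separate shares remain open. Also open, on these data alone, is whether a methyl ester or an amide in place of the carboxy would keep the low number.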